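The compounds below may be only part of what the source reports. "The series", "measured", "known", "first", "only" and "open" are said of these compounds alone.

Compound 1 `COc1cc(/C=C/C(=O)c2cccc(N)c2)ccc1O` gives 2.87 ug/mL
Compound 2 `COc1cc(/C=C/C(=O)c2cccc(NC(=O)C(C)C)c2)ccc1O` gives 1.44 ug/mL
Compound 3 `COC(=O)C(=O)Nc1cccc(C(=O)/C=C/c2ccc(O)c(OC)c2)c1` gives 1.5 ug/mL

In a functional assay on HUVEC cells (Homo sapiens) for inhibition (a lower number here means a stronger inhibitor, a higher number a weaker inhibitor), compound 3 gives 1.5 ug/mL and cannot be told apart from the other two compounds (a 1.0-fold higher number from compound 2 to compound 3 (0.02 log units; within the scatter); a 1.9-fold lower number from compound 1 to compound 3 (0.28 log units; within the scatter)). All three values lie within the usual scatter of repeated measurements, so they have no meaningful order.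

Methyl in place of methoxycarbonyl on a carbonyl carbon turns compound 3 into compound 4 `COc1cc(/C=C/C(=O)c2cccc(NC(C)=O)c2)ccc1O` (methyl in place of methoxycarbonyl on a carbonyl carbon), leaving acetyl on the nitrogen. The closest measured change sits on that same carbonyl carbon, where methoxycarbonyl in place of isopropyl made no clear difference (a 1.0-fold higher number from compound 2 to compound 3 (0.02 log units; within the scatter)). Adding either group to the nitrogen of compound 1 also gave steps within the scatter (a 2.0-fold lower number from compound 1 to compound 2 (0.30 log units; within the scatter); a 1.9-fold lower number from compound 1 to compound 3 (0.28 log units; within the scatter)). Among the compounds with values here, no measured compound carries methyl at this place, so the expectation is an extrapolation.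

The expected change is none beyond the scatter, in either direction (a 1.1-fold higher number from compound 3 to compound 4 (0.03 log units; within the scatter)). For compound 4 the estimated value is 1.6 ug/mL with an expected range from 0.75 ug/mL to 3.3 ug/mL in this assay.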

Compound 4, half-maximal inhibitory concentration: 7.06 ug/mL
The estimate for compound 4 lay 4.4-fold (0.64 log units) below the measured number; measured number outside the range, above it.
By their numbers in this assay, from the lowest: compounds 2, 3 and 1 (each within the scatter of the next); then compound 4.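

In this assay, the group on this carbonyl carbon turns out to matter: the earlier changes here stayed within the scatter, but methyl stands apart from both methoxycarbonyl (a 4.7-fold higher number from compound 3 to compound 4 (0.67 log units; beyond the scatter)) and isopropyl (a 4.9-fold higher number from compound 2 to compound 4 (0.69 log units; beyond the scatter)). Acetyl in place of hydrogen on the nitrogen also gives a step beyond the scatter (a 2.5-fold higher number from compound 1 to compound 4 (0.39 log units; beyond the scatter)), towards a weaker inhibitor. Adding a carbonyl group to this nitrogen therefore does not have one shared outcome: isopropylcarbonyl and (methoxycarbonyl)carbonyl gave steps within the scatter, whereas acetyl did not.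

Nothing measured here explains why methyl behaves differently from the other two groups. From the compounds shown here alone, it remains open whether an ethyl group or a longer chain on this carbonyl carbon would sit with methyl or with isopropyl.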